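The compounds below may be only part of what the source reports. "The series", "measured", "known", "first", "only" and "open" are said of these compounds alone.

In an ADME assay on HCT-116 cells (Homo sapiens) for cytotoxicity, read by CellTiter-Glo, with a stated time of 72 h (a higher number here means a weaker inhibitor, a lower number a stronger inhibitor), compound 2 (`CC1CCN(C2CCN(S(=O)(=O)c3cccc(Br)c3)CC2)CC1`) gives > 5000 nM as a limit of the assay, not a number. Compound 1 (`CC1CCN(C2CCN(S(=O)(=O)c3cccc(-c4ccc(F)cc4)c3)CC2)CC1`) gives > 5000 nM as a limit too. Within the data shown here, the only measured step is a step that the two limits leave unreadable from compound 1 to compound 2 and the evidence goes no further than the limit of > 5000 nM in this assay, at which 2 of the 2 values shown sit, for now. Compound 3 (`Cc1ccc(-c2cccc(S(=O)(=O)N3CCC(N4CCC(C)CC4)CC3)c2)cc1`) differs from compound 2 by one swap (4-methylphenyl in place of bromo on an aromatic carbon), 4-methylphenyl in place of bromo on an aromatic carbon. Compound 1, with 4-fluorophenyl on that carbon, gives the limit > 5000 nM as well, so no step beyond the scatter and no direction is expected. The estimated step (a step that the limit leaves unreadable from compound 2 to compound 3) is only nominal, and a reading at the limit is likely. Compound 3 is estimated at 6000 nM with 2500 nM to 15000 nM as its range.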

Compound 3, half-maximal inhibitory concentration: > 5000 nM
Compound 3 ended at the assay's limit (the forecaster's own chance of this, stated with the estimate: 80%); the middle value lies beyond the limit too.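

No step can be read among compound 1, compound 2 and compound 3: all three results are limits of the assay, not numbers. On these data alone, how strongly each compound acts in this assay stays open, as does any effect of the swaps on that aromatic carbon.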